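A few compounds are considered here, and "the series" means these few. Any claim that something is new, unique, unknown or untested is made for them only; others in the source may bear on it.

Three compounds of the series have numbers in a functional assay on MV4-11 cells (Homo sapiens) for inhibition, read by resazurin assay, with a stated time of 72 h; on this read-out lower numbers stand for stronger inhibition of growth and higher numbers for weaker inhibition of growth. Compound 1 `O=C1NCCC12CCN(c1c(Cl)cncc1-c1cc[nH]c1)CC2` gives 1050 nM, compound 2 `O=Cc1ccc(-c2cncc(Cl)c2N2CCC3(CCNC3=O)CC2)o1` gives 5190 nM, and compound 3 `Cc1ccsc1-c1cncc(Cl)c1N1CCC2(CCNC2=O)CC1` gives 910 nM. Compound 2 stands highest of the three: the steps of a 4.9-fold higher number from compound 1 to compound 2 (0.69 log units; beyond the scatter) and a 5.7-fold lower number from compound 2 to compound 3 (0.76 log units; beyond the scatter) both lie beyond the scatter, whereas a 1.2-fold lower number from compound 1 to compound 3 (0.06 log units; within the scatter) does not.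

The next compound, compound 4 `O=C1NCCC12CCN(c1c(Cl)cncc1-c1cnn(C(F)F)c1)CC2`, is not yet measured in this assay. It differs from compound 2 in one place: 1-(difluoromethyl)-1H-pyrazol-4-yl in place of 5-formylfuran-2-yl on an aromatic carbon. Going by the values given here, two measured steps bear on this change, since each exchanges the 5-formylfuran-2-yl group for another five-membered aromatic ring on the same aromatic carbon: the step of a 4.9-fold higher number from compound 1 to compound 2 (0.69 log units; beyond the scatter), which introduced that group, and the step of a 5.7-fold lower number from compound 2 to compound 3 (0.76 log units; beyond the scatter), which removed it. Both point the same way, toward a lower number once the 5-formylfuran-2-yl group is gone, each by a modest amount. Neither tested ring is the 1-(difluoromethyl)-1H-pyrazol-4-yl group, so the size of the step for compound 4 is uncertain, but a step in the same direction and of comparable size is expected. For compound 4 the estimate is 1300 nM, in the range 500 nM to 3500 nM, which corresponds to an expected step of a 4.0-fold lower number from compound 2 to compound 4 (0.60 log units; beyond the scatter).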

Compound 4, concentration for 50% growth inhibition: 6140 nM
For compound 4 the middle estimate is 4.7-fold (0.67 log units) below the measured one, outside the stated range (above it).
By their numbers in this assay, from the lowest: compounds 3 and 1 (each within the scatter of the next); then compounds 2 and 4 (each within the scatter of the next).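

In this assay, the high numbers are not tied to the 5-formylfuran-2-yl group alone: replacing it with 1-(difluoromethyl)-1H-pyrazol-4-yl gives a 1.2-fold higher number from compound 2 to compound 4 (0.07 log units; within the scatter), so these two groups cannot be told apart at this position. The new group also separates from both groups at the low end, with a 5.8-fold higher number from compound 1 to compound 4 (0.77 log units; beyond the scatter) and a 6.7-fold higher number from compound 3 to compound 4 (0.83 log units; beyond the scatter), so the four five-membered aromatic rings on this aromatic carbon, ortho to a large group, fall into two pairs, with the 1H-pyrrol-3-yl and 3-methylthiophen-2-yl groups in one and the 5-formylfuran-2-yl and 1-(difluoromethyl)-1H-pyrazol-4-yl groups in the other. No measurement at hand accounts for this split.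

Still open, going by these compounds, is whether the formyl and difluoromethyl substituents go with the higher numbers, a question that plain furan-2-yl and 1-methyl-1H-pyrazol-4-yl groups would address. Also open, on these data alone, is how a six-membered aromatic ring such as phenyl, or a non-aromatic amine, would read on the same carbon.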